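The source may hold more compounds than are shown below. What is called first, only, known or untested is meant among the compounds shown, and "the series" means these compounds.

Values in a functional assay on MCF7 cells (Homo sapiens) for inhibition, read by MTT assay, with a stated time of 3 days; on this read-out higher numbers stand for weaker inhibition and lower numbers for stronger inhibition:
- compound 1 `COc1cc(-c2nc3ccccc3s2)ccc1OCC(=O)NNC(=O)CCl`: 780 nM
- compound 2 `COc1cc(-c2nc3ccccc3s2)ccc1OCC(=O)NNC(O)CN(C)CC(=O)O`: 1960 nM

Compound 1 holds the lower of the two numbers in this assay. Compound 3 `CC[C@H](C)[C@H](NCC(=O)NNC(=O)COc1ccc(-c2nc3ccccc3s2)cc1OC)C(=O)O` differs from it by (1-carboxy-2-methylbutyl)amino in place of chloro on a saturated chain carbon bound to a carbonyl carbon, with (1-carboxy-2-methylbutyl)amino in place of chloro on a saturated chain carbon bound to a carbonyl carbon. Within the data shown here, the one measured step that bears on this is a 2.5-fold higher number from compound 1 to compound 2 (0.40 log units; beyond the scatter), a modest step that also removes the chloro and brings in an amino group with a carboxy-bearing chain. A similar modest move to a higher number is therefore expected, and the expected step is a 2.3-fold higher number from compound 1 to compound 3 (0.36 log units; beyond the scatter). Compound 3 is estimated at 1800 nM, with an expected range of 700 nM to 5000 nM.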

Compound 3, half-maximal inhibitory concentration: 1710 nM
The estimate for compound 3 lay 1.1-fold (0.02 log units) above the measured number; low and high end bracket the measured number.
By their numbers in this assay, from the lowest: compound 1; then compounds 3 and 2 (each within the scatter of the next).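

With the carbonyl kept and only the chloro replaced, this assay gives a 2.2-fold higher number from compound 1 to compound 3 (0.34 log units; beyond the scatter), so this saturated chain carbon accepts the much larger (1-carboxy-2-methylbutyl)amino group with a modest loss. Compound 3 at 1710 nM and compound 2 at 1960 nM lie within the scatter of each other, and neither reaches compound 1. No measurement offered here accounts for the step.

The compounds shown leave open whether the amine or the carboxylic acid sets this step. A methyl ester of compound 3 or a plain dimethylamino group in place of chloro would separate the two.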